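A few compounds are considered here, and "the series" means these few. Any claim that something is new, unique, unknown or untested is made for them only; others in the source may bear on it.

Measured so far in a functional assay on the whole organism (strain Swiss) with Mus musculus as the target, in the maximal electroshock model, with a stated time of 0.25 h, at a dose of 100 mg/kg by the intraperitoneal route; on this read-out higher numbers stand for a stronger effect at the one dose given and lower numbers for a weaker effect:
compound 1 `COCC(C(=O)N1CCN(c2cccc(C(F)(F)F)c2)CC1)N1C(=O)CCC1=O` — 100%
compound 2 `CC(C(=O)N1CCN(c2ccc(Cl)cc2)CC1)N1C(=O)CCC1=O` — 50%
compound 3 `CC(C(=O)N1CCN(c2ccccc2F)CC1)N1C(=O)CCC1=O` — 75%

Compound 1 stands highest of the three numbers in this assay, with compound 3 nearest and compound 2 furthest, both beyond the scatter. For the measured compounds named here, the one step available, a number 25 percentage points higher from compound 2 to compound 3 (beyond the scatter), concerns the aryl group on the ring nitrogen and not the chain carbon.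

Compound 4 `CCC(C(=O)N1CCN(c2cccc(C(F)(F)F)c2)CC1)N1C(=O)CCC1=O` is unmeasured. It differs from compound 1 by methyl in place of methoxy on a saturated chain carbon, two bonds along the chain from an amide-type nitrogen in a ring and a carbonyl carbon. Going by the values given here, no measured step bears on this change, so no direction beyond the scatter is expected; with compound 1 at the top of the scale, only a flat or lower reading is possible, and a small drop is allowed for.

The estimate for compound 4 is 88%, range 60% to 100%, meaning an expected step of a number 12 percentage points lower from compound 1 to compound 4 (beyond the scatter).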

Compound 4, a percentage reported as activity, at one dose (the size of the read-out at that dose, not a potency): 75%
Estimate against measurement, compound 4: 13 percentage points above; the range from low to high includes it.
By their numbers in this assay, from the lowest: compound 2; then compounds 3 and 4 (each within the scatter of the next); then compound 1.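

In this assay methyl in place of methoxy on the saturated chain carbon gives a number 25 percentage points lower from compound 1 to compound 4 (beyond the scatter) with the aryl group unchanged. For the compounds shown here, this is the first reading of a change at this chain carbon, and it shows that the position affects the effect at the one dose given, which the earlier step on the aryl group could not show. No measured evidence accounts for this step. Still open, as far as these compounds go, is how a longer chain, a hydroxymethyl group or an amine would read at this carbon, and whether the step holds with another aryl group.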